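The source may report more compounds than this note shows. Statements on the series, on what has been measured and on what is new or still open speak of the compounds shown alone.

In a toxicity assay on MDCK cells (Canis lupus familiaris) for cytotoxicity, read by crystal violet staining, with a stated time of 48 h (on this read-out lower numbers stand for higher toxicity in this test and higher numbers for lower toxicity in this test), compound 1 `Cc1ccc2[nH]c(=O)c(CN(Cc3ccc(O)cc3)Cc3ccc(C(C)(C)C)cc3)cc2c1` gives 4900 nM. Compound 2 `Cc1ccc2[nH]c(=O)c(CN(Cc3ccc(OC(F)(F)F)cc3)Cc3ccc(C(C)(C)C)cc3)cc2c1` reads > 5000 nM, which is a limit of the assay and not a number, so it stands at the limit of > 5000 nM in this assay, at which 1 of the 2 values shown sits.

Compound 3 `Cc1ccc2[nH]c(=O)c(CN(Cc3ccc(C(C)(C)C)cc3)C(C)c3ccc(F)cc3)cc2c1` keeps the shared core and the second arm of compound 2 but carries 1-(4-fluorophenyl)ethyl in place of 4-(trifluoromethoxy)benzyl on an amine nitrogen. Within the data shown here, only one measured step bears on this change, since it altered the same arm: an at least 1.0-fold higher number from compound 1 to compound 2 (0.00 log units; that floor lies within the scatter). Among the measured compounds shown here, that step lies within the scatter, and it is the only guide to how much this arm matters in this assay. Resting on that one step, no change beyond the scatter is expected here, although the new group has not itself been tested. The expected step is an at least 1.1-fold lower number from compound 2 to compound 3 (0.04 log units; that floor lies within the scatter), which would leave compound 3 close to the top of the readable range, and a report of a limit alone is quite possible. For compound 3 the estimated value is 4500 nM, with an expected range from 2000 nM to 5000 nM.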

Compound 3, half-maximal cytotoxic concentration: > 33000 nM
Compound 3 ended at the assay's limit; the forecaster's own chance of this, stated with the estimate: 50%; middle value at least 7.3-fold (0.86 log units) from the limit.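

With 1-(4-fluorophenyl)ethyl in place of 4-hydroxybenzyl on the amine nitrogen, this assay gives an at least 6.7-fold higher number from compound 1 to compound 3 (0.82 log units; beyond the scatter). Among these compounds, the earlier change on this arm gave only an at least 1.0-fold higher number from compound 1 to compound 2 (0.00 log units; that floor lies within the scatter), so this is the first sign that the group on this amine nitrogen can move the read-out beyond the scatter, towards lower toxicity in this test. Compound 2 and compound 3 each carry only a limit of the assay and not a number, so the step between them cannot be read, and the 4-(trifluoromethoxy)benzyl and 1-(4-fluorophenyl)ethyl arms cannot be placed in order.

Compound 3 differs from compound 1 in both the ring substituent and the methyl branch on the benzylic carbon, so the compounds shown do not tell which of these goes with the step, and 4-fluorobenzyl or 1-(4-hydroxyphenyl)ethyl on the same amine nitrogen would separate the two. From the compounds shown here alone, how a charged group on this arm, such as a carboxylic acid or a primary amine, would read in this assay also remains open.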